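A few compounds are considered here, and "the series" means these few. Any claim that something is new, unique, unknown or untested is made for them only; others in the source may bear on it.

Measured so far in a functional assay on cells for antagonist activity at C-C chemokine receptor type 4 (Homo sapiens), read by GTPgammaS binding; on this read-out higher numbers stand for weaker inhibition and lower numbers for stronger inhibition:
compound 1 `Cn1ncc2c(NS(=O)(=O)c3cccc(Cl)c3Cl)ncnc21`: 1260 nM
compound 2 `COCCOc1nn(C)c2ncnc(NS(=O)(=O)c3cccc(Cl)c3Cl)c12`: 794 nM
compound 3 `COc1nc(NS(=O)(=O)c2cccc(Cl)c2Cl)c2c(OC)nn(C)c2n1`: 794 nM

Compound 3 stands level with compound 2 at the digits given, the two together the lowest of the three numbers; the gap to compound 1 is within the scatter. The step to compound 4 `COc1nn(C)c2nc(NC(C)C)nc(NS(=O)(=O)c3cccc(Cl)c3Cl)c12` is isopropylamino in place of methoxy on an aromatic carbon. For the measured compounds named here, no measured pair carries this change. Going by the values given here, the only step in hand, a 1.6-fold lower number from compound 1 to compound 2 (0.20 log units; within the scatter), concerns a group elsewhere on the shared core and stayed within the scatter, so it offers no lead on the present change. No step beyond the scatter is therefore expected in this assay; the expected step is a 1.1-fold lower number from compound 3 to compound 4 (0.05 log units; within the scatter). Compound 4 is estimated at 700 nM, range 250 nM to 2000 nM.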

Compound 4, half-maximal inhibitory concentration in the C-C chemokine receptor type 4 assay: 3160 nM
Estimate against measurement, compound 4: 4.5-fold (0.65 log units) below; measured number above the stated range.
By their numbers in the C-C chemokine receptor type 4 assay, from the lowest: compounds 2, 3 and 1 (each within the scatter of the next); then compound 4.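

In the C-C chemokine receptor type 4 assay, isopropylamino in place of methoxy on the aromatic carbon between two ring nitrogen atoms gives a 4.0-fold higher number from compound 3 to compound 4 (0.60 log units; beyond the scatter), so this position is not neutral for inhibition. This is the only step shown that lies beyond the scatter in that assay. In a physicochemical assay for lipophilicity (a higher number here means a more lipophilic compound, a lower number a more polar compound), compound 3 gives 1.9 and compound 4 gives 5.2. In the physicochemical assay, the weaker inhibition comes with much higher lipophilicity: the measured distribution coefficient of compound 3, 1.9, and of compound 4, 5.2, a number 3.30 log units higher (beyond the scatter)

A single pair cannot separate the roles of size, the added hydrogen-bond donor and lipophilicity. On these data alone, it remains open how a dimethylamino group, which has no amine hydrogen, or a morpholine ring would behave at this position.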